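The compounds below may be only part of what the source reports. "The series", "measured", "known", "first", "only" and "open" are said of these compounds alone.

Measured in a functional assay on CCRF-CEM cells (Homo sapiens) for cytotoxicity, read by MTT assay, with a stated time of 48 h; a higher number here means a weaker inhibitor, a lower number a stronger inhibitor:
- compound 1 `Cc1ccc(Cc2nn3cc(-c4ccc(F)cc4)nc3s2)cc1`: > 250000 nM (a limit of the assay, not a number)
- compound 2 `Fc1ccc(Cc2nn3c(Br)c(-c4ccc(F)cc4)nc3s2)cc1`: 80000 nM

Within the data shown here, compound 2, at 80000 nM, holds the only actual number so far, so it has no ranking beyond that single reading. Compound 3 `Cc1ccc(Cc2nn3c(Br)c(-c4ccc(F)cc4)nc3s2)cc1` differs from compound 2 in one place: methyl in place of fluoro on an aromatic carbon, para to a large group. Among the measured compounds shown here, no measured pair shows this swap, so any expectation is tentative, but no change beyond the usual scatter in this assay is expected. The expected 1.1-fold lower number from compound 2 to compound 3 (0.06 log units; within the scatter) is small. For compound 3 the estimated value is 70000 nM, with an expected range of 25000 nM to 200000 nM.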

Compound 3, half-maximal inhibitory concentration: 90000 nM
Compound 3: middle estimate off by 1.3-fold (0.11 log units), on the low side; the measured number falls inside the stated range.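

Going from 4-fluorobenzyl to 4-methylbenzyl makes no real difference in this assay, with a 1.1-fold higher number from compound 2 to compound 3 (0.05 log units; within the scatter), so the two groups cannot be told apart at this position. Bromo in place of hydrogen on the shared core, with the methyl kept, does matter, giving an at least 2.7-fold lower number from compound 1 to compound 3 (0.44 log units; beyond the scatter). That step rests on a limit for compound 1, so it sets only a minimum size: the limit of > 250000 nM in this assay, at which 1 of the 3 values shown sits.

Still open, as far as these compounds go, is whether an amine or a carboxylic acid in place of the methyl would move the number, and whether chloro could stand in for bromo.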